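Triazole aryl swap: methylphenyl to chlorophenyl

The source may report more compounds than this note shows. Statements on the series, on what has been measured and on what is new or still open speak of the compounds shown alone.

Compound 1 `N#CC1=C(N)Oc2c(c3nc4ccccc4nc3c3ccccc23)C12C(=O)N(Cc1cnnn1-c1cccc(Cl)c1)c1ccccc12` gave 32600 nM in a functional assay on A549 cells (Homo sapiens) for antiproliferative activity, read by MTT assay, with a stated time of 48 h; a lower number here means a stronger inhibitor, a higher number a weaker inhibitor. Compound 2 `N#CC1=C(N)Oc2c(c3nc4ccccc4nc3c3ccccc23)C12C(=O)N(Cc1cnnn1-c1ccccc1Br)c1ccccc12` reached only > 50000 nM in this assay; that is a limit of the assay, not a number. Compound 3 `Cc1cccc(-n2nncc2CN2C(=O)C3(C(C#N)=C(N)Oc4c(N)cc5nc6ccccc6nc5c43)c3ccccc32)c1` gave 12300 nM in this assay.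

Of the two numbers, compound 3 gives the lowest, sitting beyond the scatter from compound 1. Compound 4 `N#CC1=C(N)Oc2c(N)cc3nc4ccccc4nc3c2C12C(=O)N(Cc1cnnn1-c1ccc(Cl)cc1)c1ccccc12` differs from compound 3 by 4-chlorophenyl in place of 3-methylphenyl on an aromatic nitrogen. Among the measured compounds shown here, the only measured step on this part, an at least 1.5-fold higher number from compound 1 to compound 2 (0.18 log units; that floor lies within the scatter), swapped one halogen-bearing phenyl for another and ended at the limit of > 50000 nM in this assay, at which 1 of the 3 values shown sits, so its true size is unknown. For the measured compounds named here, no measured step exchanges a methylphenyl for a chlorophenyl. The expected step of a 1.3-fold higher number from compound 3 to compound 4 (0.11 log units; within the scatter) for compound 4 is therefore small, in no certain direction. Compound 4 is estimated at 16000 nM (range 5000 nM to 50000 nM).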

Compound 4, half-maximal inhibitory concentration: > 50000 nM
Compound 4 ended at the assay's limit (the forecaster's own chance of this, stated with the estimate: 15%); at least 3.1-fold (0.49 log units) between middle value and limit.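

Swapping the aryl group on the aromatic nitrogen gives an at least 4.0-fold higher number from compound 3 to compound 4 (0.60 log units; beyond the scatter) in this assay, so unlike the earlier step, this change clearly registers at this position. The value of compound 4 is a limit of the assay, not a number, so the step is only a floor: the limit of > 50000 nM in this assay, at which 2 of the 4 values shown sit. The change also alters two things at once, the substituent and its ring position, and these cannot be separated here.

On these data alone, whether 4-methylphenyl or unsubstituted phenyl on the same core would keep the activity of compound 3 remains open.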